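A few compounds are considered here, and "the series" means these few. Any claim that something is new, unique, unknown or untested is made for them only; others in the source may bear on it.

Of the compounds shown here, three sharing one core have been measured in a functional assay on CHO cells for agonist activity at Free fatty acid receptor 1 (Homo sapiens), read by FLIPR and calcium flux, in the presence of a further agent that is not named here; a higher number here means that more compound is needed for the effect, a lower number that less compound is needed. Compound 2 `O=C(O)CCc1ccc(OCc2nc(-c3ccccc3)no2)cc1` gives 1130 nM, compound 3 `O=C(O)CCc1ccc(OCc2nc(-c3ccc(F)cc3)no2)cc1` gives 680 nM, and compound 1 `O=C(O)CCc1ccc(OCc2nc(-c3cccc(C(F)(F)F)c3)no2)c(Cl)c1` gives 30100 nM. Among these three numbers compound 2 stands second highest, nearest to compound 3 and furthest from compound 1. Among the compounds with values here, the only single-point step available, a 1.7-fold lower number from compound 2 to compound 3 (0.22 log units; within the scatter), lies within the scatter. Compound 4 `O=C(O)CCc1ccc(OCc2nc(-c3cccc(C(F)(F)F)c3)no2)cc1` differs from compound 2 by trifluoromethyl in place of hydrogen on an aromatic carbon. Within the data shown here, no measured step mirrors this change directly; compound 1 carries the same trifluoromethyl together with a chloro group, so its value cannot be read as a step. The step to compound 4 is therefore expected to be modest, a 1.3-fold higher number from compound 2 to compound 4 (0.12 log units; within the scatter). Compound 4 is estimated at 1500 nM, within 400 nM to 6000 nM.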

Compound 4, half-maximal effective concentration: 1110 nM
Compound 4: middle estimate off by 1.4-fold (0.13 log units), on the high side; measured number inside the range.
By their numbers in this assay, from the lowest: compounds 3, 4 and 2 (each within the scatter of the next); then compound 1.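

Trifluoromethyl in place of hydrogen, on an aromatic carbon meta to a large group, changes the number only within the scatter, with a 1.0-fold lower number from compound 2 to compound 4 (0.01 log units; within the scatter). The large gap seen with compound 1 now traces to a single change, hydrogen in place of chloro on an aromatic carbon, which gives a 27-fold lower number from compound 1 to compound 4 (1.43 log units; beyond the scatter). No evidence at hand accounts for either step.

As far as these compounds go, whether an amine or a nitrile at this position would match trifluoromethyl stays open. So does whether chloro would cost as much on compound 2, which lacks trifluoromethyl.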